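Methyl to Chloro Beside an Inactive Parent

The compounds below may be only part of what the source reports. "The series", "measured", "known", "first", "only" and "open" are said of these compounds alone.

Compound 1 `Cc1cc(-n2cc(C(=O)Nc3cc(F)cc(F)c3)c(=O)c3ccc(N(C)C)nc32)ccc1OCCCCCCC[N+]12CCN(CC1)CC2` and compound 2 `CN(C)c1ccc2c(=O)c(C(=O)Nc3cc(F)cc(F)c3)cn(-c3ccc(OCCCCCCC[N+]45CCN(CC4)CC5)c(Cl)c3)c2n1` share one core and differ only by chloro in place of methyl on an aromatic carbon. In an assay on LX2 cells for inhibition of COL1A1 promoter (Homo sapiens), read by a luciferase reporter, with a stated time of 24 h, tested at 50 uM (on this read-out lower numbers stand for a weaker effect and higher numbers for a stronger effect at the one concentration tested), compound 1 gives 20.8%, and compound 2 gives 20.5%, so the step of a number 0.3 percentage points lower from compound 1 to compound 2 (within the scatter) is small. Compound 3 `Cc1cc(OCCCCCCC[n+]2ccccc2)ccc1-n1cc(C(=O)Nc2cc(F)cc(F)c2)c(=O)c2ccc(N(C)C)nc21` is built differently; the difference between its core and that of compound 1 is not broken down here. In this assay compound 3 is reported as "not active" (no number reported). Compound 4 `CN(C)c1ccc2c(=O)c(C(=O)Nc3cc(F)cc(F)c3)cn(-c3ccc(OCCCCCCC[n+]4ccccc4)cc3Cl)c2n1` stands to compound 3 as compound 2 stands to compound 1, the same change, (chloro in place of methyl on an aromatic carbon), with the same words around the place. Because the step of a number 0.3 percentage points lower from compound 1 to compound 2 (within the scatter) stayed within the scatter, and because compound 3 shows "not active" (no number reported), the expectation for compound 4 is a weak effect, estimated at 5%, most likely between -10% and 20%.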

Compound 4, a percentage reported as inhibition, at one concentration (the size of the read-out at that concentration, not a potency): "not active" (no number reported)
Compound 4: no number reported, so the estimate cannot be set against anything.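

Compound 3 and compound 4 both stand without a number in this assay, so no step can be read between them. On these data alone, whether chloro in place of methyl alters the effect on this core stays open. No measured evidence bears on this result.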